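A few compounds are considered here, and "the series" means these few. Any claim that something is new, unique, unknown or untested is made for them only; others in the source may bear on it.

Compound 1 `Cc1c(Nc2nc(N)c3c(C#N)c(N4CCC[C@H]4C)n(C)c3n2)cnn1[C@H]1CCOC1` carries an oxolan-3-yl group on an aromatic nitrogen of its five-membered aromatic ring. In an ADME assay on microsomes from liver (Homo sapiens) for pharmacokinetics (on this read-out lower numbers stand for slow clearance and higher numbers for fast clearance), compound 1 gives 23.3 mL/min/kg, which is the lowest of the two numbers recorded so far. Among the compounds with values here, compound 2 `Cc1nn(CC(C)(C)O)cc1Nc1nc(N)c2c(C#N)c(N3CCC[C@H]3C)n(C)c2n1` differs from compound 1 in more than one place, so no single step links the two; in this assay compound 2 gives 50 mL/min/kg, a number that lies beyond the scatter above that of compound 1.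

Compound 3 `Cc1c(Nc2nc(N)c3c(C#N)c(N4CCC[C@H]4C)n(C)c3n2)cnn1CC(C)(C)O` has not yet been measured. Against compound 1 the change is 2-hydroxy-2-methylpropyl in place of oxolan-3-yl on an aromatic nitrogen. The group that enters is the same one found in compound 2, and because compound 2 shows 50 mL/min/kg the expectation is that compound 3 moves toward faster clearance rather than staying level with compound 1. The step from compound 1 to compound 3 is estimated as a 1.7-fold higher number from compound 1 to compound 3 (0.23 log units; within the scatter), a moderate rise that should clear the usual scatter. Compound 3 is therefore expected to give about 40 mL/min/kg, within a range from 25 mL/min/kg to 65 mL/min/kg.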

Compound 3, clearance: 30 mL/min/kg
Compound 3: the middle estimate sits 1.3-fold (0.12 log units) above what was measured, and the stated range covers the measured number.
By their numbers in this assay, from the lowest: compounds 1, 3 and 2 (each within the scatter of the next, the first and the last beyond it).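

In this assay, 2-hydroxy-2-methylpropyl in place of oxolan-3-yl on an aromatic nitrogen of the five-membered aromatic ring gives a 1.3-fold higher number from compound 1 to compound 3 (0.11 log units; within the scatter), so this read-out does not tell the two groups apart. Within the data shown here, this is the first comparison in which only this position differs, and the earlier compounds could not isolate it. Here the ring and the defined stereocentre of oxolan-3-yl are gone and a hydrogen-bond donor is present, while the heavy-atom count stays the same, and the two numbers still lie within the scatter of each other.

From the compounds shown here alone, whether a piperidin-4-yl group with its ring amine, a carboxylic acid or a longer chain on the same nitrogen would also stay within the scatter of compound 1 remains open. Nothing at hand explains why these two groups give numbers so close together.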